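Amino for sulfamoyl on compound 1

A few compounds are considered here, and "the series" means these few. Any claim that something is new, unique, unknown or untested is made for them only; others in the source may bear on it.

In a toxicity assay on Huh-7.5 cells (Homo sapiens) for inhibition, read by MTT assay, with a stated time of 96 h (a higher number here means that more compound is tolerated, a lower number that less compound is tolerated), compound 1 (`CN1CCN(Cc2ccc(NC(=O)c3ccc(OCCCCl)c(S(N)(=O)=O)c3)cc2C(F)(F)F)CC1`) gives 5470 nM and lies within the scatter of compound 3 (`CC(C)Oc1ccc(C(=O)Nc2ccc(CN3CCN(C)CC3)c(C(F)(F)F)c2)cc1NC(=O)C(C)Br`) at 8700 nM but clearly lower than compound 2 (`CCC(=O)Nc1cc(C(=O)Nc2ccc(CN3CCN(C)CC3)c(C(F)(F)F)c2)ccc1OC(C)C`) at 15300 nM on this scale. Compound 4 (`CN1CCN(Cc2ccc(NC(=O)c3ccc(OCCCCl)c(N)c3)cc2C(F)(F)F)CC1`) carries amino in place of sulfamoyl on an aromatic carbon, ortho to a 3-chloropropoxy group. Among the compounds with values here, the only measured step (a 1.8-fold lower number from compound 2 to compound 3 (0.25 log units; within the scatter)) is bromo in place of hydrogen on a saturated chain carbon, a different change that stays within the scatter. Within the data shown here, no measured pair shows the loss of sulfamoyl, so the data offer little guidance. A step within the scatter is expected in this assay (estimated as a 1.3-fold higher number from compound 1 to compound 4 (0.11 log units; within the scatter)). Compound 4 is estimated at 7000 nM (expected range 2500 nM to 20000 nM).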

Compound 4, half-maximal cytotoxic concentration: 12900 nM
Beside the measured number, compound 4's estimate is 1.8-fold (0.27 log units) below it; the range from low to high includes it.
By their numbers in this assay, from the lowest: compounds 1, 3, 4 and 2 (each within the scatter of the next, the first and the last beyond it).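

In this assay, amino in place of sulfamoyl on this aromatic carbon gives a 2.4-fold higher number from compound 1 to compound 4 (0.37 log units; beyond the scatter), a modest step beyond the scatter. Within the data shown here, this is the first measured change at this position, and it shows that the number here responds to the group on this carbon, whereas the earlier step concerned a saturated chain carbon. The compounds shown offer no measured basis for explaining this step. On these data alone, whether a carboxylic acid or a methylsulfonyl group here would fall nearer compound 1 or compound 4 remains open, as does whether the step would persist without the 3-chloropropoxy group.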